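The source may hold more compounds than are shown below. What is called first, only, known or untested is meant among the compounds shown, and "the series" means these compounds.

Measured in an ADME assay on Vero cells (Chlorocebus sabaeus) for cytotoxicity, read by MTT assay, with a stated time of 72 h; a higher number here means that more compound is needed for the effect, a lower number that less compound is needed:

- compound 1 `COc1ccc(C(=O)Nc2nc(-c3ccccn3)cs2)cc1`: 9200 nM
- compound 2 `CC(=O)c1cccc(C(=O)Nc2nc(-c3ccccn3)cs2)c1`: 1500 nM
- compound 3 `O=C(Nc1nc(-c2ccccn2)cs1)c1cccc([N+](=O)[O-])c1`: "not determined" (no result reported)

Compound 3 has no place on this scale, since its entry in this assay is "not determined" (no result reported): no result was reported for it. It therefore cannot be ranked against the two compounds that do have numbers. Those two share a core with it and differ in the group on the carbon-only aromatic ring. Compound 1 reads 9200 nM, while compound 2 reads 1500 nM, so compound 2 needs less compound for the effect.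

The next compound is compound 4 `O=C(Nc1nc(-c2ccccn2)cs1)c1cccc(Cl)c1`. The change is chloro in place of nitro on an aromatic carbon, which is chloro in place of nitro on an aromatic carbon, and the shared core stays as it is.

Among the compounds with values here, with no number for compound 3, this step has no measured starting point, and the data offer no direct example of such a swap. No direction can be favoured, and a step of modest size is expected. The best guide is the span from compound 2 at 1500 nM to compound 1 at 9200 nM, and compound 4 is expected to fall in or near that span.

For compound 4 the expected value is 3800 nM, with an estimated range from 1000 nM to 14000 nM.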

Compound 4, half-maximal effective concentration: 7000 nM
The estimate for compound 4 lay 1.8-fold (0.27 log units) below the measured number; measured number inside the range.
By their numbers in this assay, from the lowest: compound 2; then compounds 4 and 1 (each within the scatter of the next).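

In this assay the swap of nitro for chloro cannot be read, since compound 3 has no number to start from. Within the data shown here, the new result does supply the first measured one-place comparison: with chloro in place of acetyl on the aromatic carbon meta to a large group, the data show a 4.7-fold higher number from compound 2 to compound 4 (0.67 log units; beyond the scatter) and this step lies beyond the usual scatter. The group at this single position can therefore change how much compound is needed for the effect on these cells, and in this one pair the chloro compound needs more than the acetyl compound.

On these data alone, this rests on a single pair, so it remains open how other groups at this position, such as an amine, a carboxylic acid or a longer chain, would compare with chloro and acetyl. Nothing in the information available accounts for the size or direction of this step.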